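Series cytotoxicity notes: from compound 1 to compound 3

This account rests on a few compounds, and the source may have more. Where it says the series, first, only, none or still open, it means among the compounds named here.

Compound 1 `CCCC(=O)OCSc1ccccc1C(=O)NC1(C(N)=O)CCCC1` and compound 2 `CCCC(=O)OCSc1ccccc1C(=O)OCC(N)=O` share the same core. In an ADME assay on CEM-SS cells (Homo sapiens) for cytotoxicity, read by XTT assay, with a stated time of 6 days (on this read-out higher numbers stand for lower toxicity in this test and lower numbers for higher toxicity in this test), compound 1 gives > 100 uM, which is a limit of the assay and not a number (the limit of > 100 uM in this assay, at which 1 of the 2 values shown sits). In this assay compound 2 gives 82.1 uM. Compound 3 `CCCC(=O)OCSc1ccccc1C(N)=O` is not yet measured; it differs from compound 1 by hydrogen in place of 1-carbamoylcyclopentyl on an amide-type nitrogen. Among the measured compounds shown here, no step between measured compounds exists for this change, so in this assay no shift beyond the usual scatter is expected in either direction. Compound 3 is estimated at 100 uM, expected between 40 uM and 250 uM. The expected step is a number no higher from compound 1 to compound 3 (the limit leaves the size open).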

Compound 3, half-maximal toxic concentration: 12.4 uM
For compound 3 the middle estimate is 8.1-fold (0.91 log units) above the measured one, and the stated range ends above it.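

In this assay, hydrogen in place of 1-carbamoylcyclopentyl on an amide-type nitrogen gives an at least 8.0-fold lower number from compound 1 to compound 3 (0.90 log units; beyond the scatter), and amino in place of carbamoylmethoxy on a carbonyl carbon gives a 6.6-fold lower number from compound 2 to compound 3 (0.82 log units; beyond the scatter). This position is therefore not silent: both changes end at compound 3 with a lower number, which stands for higher toxicity in this test. The value of compound 1 is a limit of the assay and not a number: the limit of > 100 uM in this assay, at which 1 of the 3 values shown sits.

Going by these compounds, whether methyl or a longer alkyl chain on the amide-type nitrogen would bring the number back up remains open.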